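Swapping a dichlorophenyl for a dimethoxyphenyl on the carbonyl

The source may report more compounds than this note shows. Statements on the series, on what has been measured and on what is new or still open speak of the compounds shown alone.

Measured so far:
- compound 1, `COc1ccc(-c2cc(/C=C/C(=O)c3ccc(OC)c(OC)c3)[nH]n2)cc1`: -28%
- compound 2, `COc1cc(-c2cc(/C=C/C(=O)c3ccc(Cl)c(Cl)c3)[nH]n2)cc(OC)c1OC`: 9%
- compound 3, `COc1ccc(-c2cc(/C=C/C(=O)c3cc(OC)c(OC)c(OC)c3)[nH]n2)cc1OC`: -37%

These three compounds share a core in which a pyrazole carries an aryl group on one side and, through a double-bonded chain carbon, a carbonyl carrying a second aryl group. The assay is a functional assay on T47D cells (Homo sapiens) for cytotoxicity, read by sulforhodamine B assay, with a stated time of 48 h, tested at 10 uM; a higher number here means a weaker effect of the compound at the concentration tested, a lower number a stronger effect. Among the three, compound 2 has the highest number: its value stands well apart from compound 1 and even further from compound 3, in both cases beyond the scatter, so compound 2 shows the weakest effect of the three at the tested concentration.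

The next compound, compound 4, `COc1ccc(C(=O)/C=C/c2cc(-c3cc(OC)c(OC)c(OC)c3)n[nH]2)cc1OC`, has not yet been measured. It differs from compound 2 in one place: 3,4-dimethoxyphenyl in place of 3,4-dichlorophenyl on a carbonyl carbon. Compound 4 also carries a trimethoxyphenyl on the pyrazole, as compound 2 does.

Compound 1 and compound 3, which both carry a methoxy-bearing aryl group on the carbonyl carbon, give clearly lower numbers than compound 2, whose carbonyl bears the dichlorophenyl. From this the step from compound 2 to compound 4 is expected to be downward and beyond the scatter, about a number 37 percentage points lower from compound 2 to compound 4 (beyond the scatter). For compound 4 a value of about -28% is expected, within a range from -60% to 5%.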

Compound 4, a percentage reported as activity, at one concentration (the size of the read-out at that concentration, not a potency): -42%
Compound 4: the middle estimate sits 14 percentage points above what was measured; low and high end bracket the measured number.
By their numbers in this assay, from the lowest: compounds 4, 3 and 1 (each within the scatter of the next, the first and the last beyond it); then compound 2.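

In this assay, going by these compounds alone, the earlier compounds differed in more than one place, so none of them could show what the group on the carbonyl carbon does by itself. Placing 3,4-dimethoxyphenyl where 3,4-dichlorophenyl stood gives a number 51 percentage points lower from compound 2 to compound 4 (beyond the scatter), with the trimethoxyphenyl and the rest of the molecule unchanged, so this single change on a carbonyl carbon is enough to turn a weak effect at the tested concentration into a much stronger one, and the trimethoxyphenyl shared by both compounds does not by itself fix the outcome. Nothing measured here explains why the swap of 3,4-dichlorophenyl for 3,4-dimethoxyphenyl has so large an effect.

The compounds shown leave open whether the two methoxy groups are both needed, and whether a ring carrying one chlorine and one methoxy would sit nearer compound 2 or compound 4. They also leave open whether an amine or a carboxylic acid on this ring would keep the stronger effect, and whether the same swap gives a step of this size when a different aryl group stands elsewhere in the molecule.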